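This account rests on a few compounds, and the source may have more. Where it says the series, first, only, none or still open, it means among the compounds named here.

Compound 1 `Cc1cccc(-n2nncc2CN2C(=O)C3(C(C#N)=C(N)Oc4c3c3nc5ccccc5nc3c3ccccc43)c3ccccc32)c1` was run in an ADME assay on L02 cells (Homo sapiens) for antiproliferative activity, read by MTT assay, with a stated time of 48 h; a lower number here means a stronger inhibitor, a higher number a weaker inhibitor. In this assay compound 1 gives only the limit of the assay, > 50000 nM. Compound 2 `N#CC1=C(N)Oc2c(c3nc4ccccc4nc3c3ccccc23)C12C(=O)N(Cc1cnnn1-c1ccc(Cl)cc1)c1ccccc12` in this assay likewise gives only a limit, > 50000 nM. The step that the two limits leave unreadable from compound 1 to compound 2 is therefore not readable. Compound 3 `N#CC1=C(N)Oc2c(N)cc3nc4ccccc4nc3c2C12C(=O)N(Cc1cnnn1-c1cccc(Br)c1)c1ccccc12` also gives in this assay only a limit, > 50000 nM. Within the data shown here, its standing rests on (the limit of > 50000 nM in this assay, at which 3 of the 3 values shown sit), so no step has a readable size. Compound 4 `N#CC1=C(N)Oc2c(N)cc3nc4ccccc4nc3c2C12C(=O)N(Cc1cnnn1-c1cc(Cl)ccc1Cl)c1ccccc12` differs from compound 3 by 2,5-dichlorophenyl in place of 3-bromophenyl on an aromatic nitrogen. Among the measured compounds shown here, no measured step bears on this change, and every value seen sits at a limit, so no step beyond the scatter is expected. The step expected from this is a step that the limit leaves unreadable from compound 3 to compound 4. Compound 4 is estimated at 80000 nM, between 30000 nM and 250000 nM, most likely again reported only as a limit.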

Compound 4, half-maximal inhibitory concentration: > 50000 nM
Compound 4 ended at the assay's limit; the forecaster's own chance of this, stated with the estimate: 85%; the middle value lies beyond the limit too.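

No step can be read from compound 3 to compound 4, which both give only a limit: the limit of > 50000 nM in this assay, at which 4 of the 4 values shown sit.
The compounds shown leave open whether changing the group on the aromatic nitrogen shifts the read-out at all in this assay.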